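A few compounds are considered here, and "the series" means these few. Any claim that something is new, unique, unknown or untested is made for them only; others in the source may bear on it.

Measured so far in an assay on HEK293 cells for displacement of a labelled ligand from NPC1-like intracellular cholesterol transporter 1 (Homo sapiens); a higher number here means a weaker inhibitor, a lower number a stronger inhibitor:

- compound 1, `CC(C)(C)c1ccc(C(=O)N2CCC3(CC2)C(=O)N(CC(=O)NCN)CN3c2ccccc2)cc1`: 26500 nM
- compound 2, `CC(C)(C)OC(=O)NC1CCCN(C(=O)CN2CN(c3ccccc3)C3(CCN(C(=O)c4ccc(C(C)(C)C)cc4)CC3)C2=O)C1`: 4200 nM
- compound 3, `CC(C)(C)OC(=O)NC1CCN(C(=O)CN2CN(c3ccccc3)C3(CCN(C(=O)c4ccc(C5CCCCC5)cc4)CC3)C2=O)CC1`: 4800 nM

Compound 1 stands at the highest of these three numbers. Compound 3 is nearest to it with a lower number, and compound 2 gives a lower number still; both gaps lie beyond the usual scatter of this assay, so compound 1 is the weakest of the three measured compounds.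

Compound 4, `CC(C)(C)c1ccc(C(=O)N2CCC3(CC2)C(=O)N(CC(=O)NCCCCNS(C)(=O)=O)CN3c2ccccc2)cc1`, has not yet been measured. It differs from compound 1 in one place:

3-(methanesulfonamido)propyl in place of amino on a saturated chain carbon bound to an amide-type nitrogen

Read one bond further out, the same change turns (aminomethyl)carbamoyl into (4-(methanesulfonamido)butyl)carbamoyl. The entering group is the larger of the two, as the count shows.

Within the data shown here, no pair of measured compounds isolates this change, so the expectation can only lean on the general picture: the two measured compounds whose structures extend beyond that of compound 1, compounds 2 and 3, both give lower numbers than compound 1, and that makes a step toward a lower number the more likely outcome, though of moderate size. The step expected is a 3.3-fold lower number from compound 1 to compound 4 (0.52 log units; beyond the scatter). For compound 4 in this assay the estimate is 8000 nM, with a range from 2500 nM to 25000 nM.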

Compound 4, half-maximal inhibitory concentration: 4500 nM
Compound 4: middle estimate off by 1.8-fold (0.25 log units), on the high side; the range from low to high includes it.
By their numbers in this assay, from the lowest: compounds 2, 4 and 3 (each within the scatter of the next); then compound 1.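

Among these compounds, replacing amino with 3-(methanesulfonamido)propyl on a saturated chain carbon bound to an amide-type nitrogen gives, in this assay, a 5.9-fold lower number from compound 1 to compound 4 (0.77 log units; beyond the scatter), and this is the first change in the set that can be read at a single place. The position therefore accepts a much larger group, 8 heavy atoms where 1 stood, with no loss of inhibition; the number falls instead. The swap alters the chain length and the group at its end together, and nothing measured here explains the fall or shows which of the two alterations matters.

A plain butyl chain or a 4-aminobutyl chain, which ends in a free amine, on the same core would help to separate the effect of chain length from that of the methanesulfonamide end. A carboxylic acid at the end of the same chain, or a methanesulfonamide on a shorter chain, would show how much the result depends on that end group and on its distance from the core.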